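This account rests on a few compounds, and the source may have more. Where it says the series, first, only, none or still open, it means among the compounds named here.

Measured in a functional assay on A549 cells (Homo sapiens) for cytotoxicity, read by MTT assay, with a stated time of 72 h; a lower number here means a stronger inhibitor, a higher number a weaker inhibitor:

Compound 1 `O=C(CN1CCN(c2nnc(Cc3ccccc3)c3ccccc23)CC1)Nc1c(F)cccc1F`: 84500 nM
Compound 2 `O=C(CN1CCN(c2nnc(Cc3ccncc3)c3ccccc23)CC1)Nc1ccc(F)c(Cl)c1`: 12300 nM

Of these two, compound 2 has the lower number, and its gap to compound 1 lies beyond the scatter, which makes compound 2 the stronger inhibitor of the pair. The two compounds differ in more than one place, so their values isolate no single structural change.

Compound 3 `O=C(CN1CCN(c2nnc(Cc3ccccc3)c3ccccc23)CC1)Nc1ccc(F)c(Cl)c1` departs from compound 2 in one place: phenyl in place of pyridin-4-yl on a saturated chain carbon bound to an aromatic carbon. Compound 1 also carries phenyl there, but at 84500 nM compound 1 differs from compound 3 elsewhere too, so it says little about this swap. Going by the values given here, with no measured step to guide it, the expectation in this assay is a small shift, none beyond the scatter, with the number if anything slightly higher. The expected change is a 1.3-fold higher number from compound 2 to compound 3 (0.11 log units; within the scatter). For compound 3 the estimated value is 16000 nM, with an expected range from 5500 nM to 46000 nM.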

Compound 3, half-maximal inhibitory concentration: "not active" (no number reported)
No number was reported for compound 3; the estimate stays without a comparison.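

In this assay, going by these compounds alone, compound 3 was reported as not active, without a number, and no step from compound 2 to compound 3 can be read. As far as these compounds go, how far the change from pyridin-4-yl to phenyl moves the number remains open. No measurement shown here offers an explanation for this result.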